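This account rests on a few compounds, and the source may have more. Where it says the series, first, only, none or still open, it means among the compounds named here.

Compound 1 `O=C(O)CCc1ccc(OCc2ccccc2)c(I)c1`: 81%
Compound 2 `O=C(O)CCc1ccc(OCc2ccccc2Br)cc1`: 99%
Compound 3 `O=C(O)CCc1ccc(OCc2cccc(Br)c2)cc1`: 99%

In a functional assay on 1321-N1 cells for agonist activity at Free fatty acid receptor 1 (Homo sapiens), read by calcium flux (a lower number here means a smaller maximal response, a higher number a larger maximal response), compound 3 stands level with compound 2, the two together giving the highest of the three numbers; compound 1 lies further off, with a smaller maximal response that falls beyond the usual scatter. Compound 4 `N#Cc1cccc(COc2ccc(CCC(=O)O)cc2)c1` has not yet been measured. It differs from compound 3 in a single respect: cyano in place of bromo on an aromatic carbon. Within the data shown here, with no measured pair showing what this exchange does, the expectation rests only on compound 3 itself. The step from compound 3 to compound 4 is expected to be small, a number 7 percentage points lower from compound 3 to compound 4 (within the scatter), most likely within the scatter, with any real change more likely downward since compound 3 already sits near the top of the range. Compound 4 is therefore expected to give 92% in this assay, with a range from 75% to 105%.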

Compound 4, largest response reached (reported as efficacy), in percent of the reference or control that the assay uses: 102%
Compound 4: middle estimate off by 10 percentage points, on the low side; measured number inside the range.
By their numbers in this assay, from the lowest: compound 1; then compounds 2, 3 and 4 (each within the scatter of the next).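

In this assay, among these compounds, cyano in place of bromo on an aromatic carbon, meta to a large group, gives a number 3 percentage points higher from compound 3 to compound 4 (within the scatter) as the first single-place step. This position therefore accepts a nitrile as well as a bromo group while the maximal response stays at the top of the range. Nothing at hand explains this tolerance.

Going by these compounds, whether an amine, a methoxy group or a carboxylic acid at this place would keep the response remains open. So does whether cyano in place of the bromo of compound 2 would give the same result.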